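The source may hold more compounds than are shown below. What is called first, only, known or untested is meant among the compounds shown, and "the series" means these compounds.

Of the compounds shown here, two of one shared core have been measured so far. Compound 1 `COc1ccc(Cl)cc1NC(=O)[C@@H](C)N1CCN(S(=O)(=O)N2CCC(C(F)(F)F)CC2)CC1` gives 3500 nM in an assay on HEK293 cells for inhibition of potassium channel subfamily T member 1 (Homo sapiens), read by thallium flux (on this read-out higher numbers stand for weaker inhibition and lower numbers for stronger inhibition), and its mirror-image partner compound 2 `COc1ccc(Cl)cc1NC(=O)[C@H](C)N1CCN(S(=O)(=O)N2CCC(C(F)(F)F)CC2)CC1` gives 3400 nM in the same assay. Within the data shown here, the only step among the measured pairs, a 1.0-fold lower number from compound 1 to compound 2 (0.01 log units; within the scatter), is within the scatter, which matches the fact that these two share every atom and bond and differ only in configuration as drawn (the fact that compounds 1 and 2 differ only in the configuration as drawn). On the numbers shown, compound 2 therefore sits alongside compound 1, with nothing that separates them.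

Compound 3 `COc1ccc(Cl)cc1NC(=O)[C@H](C)N1CCN(S(=O)(=O)N2CCC(C)CC2)CC1` is not yet measured. It differs from compound 2 in one place: methyl in place of trifluoromethyl on a saturated ring carbon. Among the measured compounds shown here, no measured step touches this position or this kind of exchange; the only step available concerns configuration alone, so it gives no guide to the size or direction of what this swap may do in this assay. The expectation for compound 3 is therefore a step of a 1.5-fold higher number from compound 2 to compound 3 (0.17 log units; within the scatter), with a wide range, and compound 3 is estimated at 5000 nM, between 1500 nM and 16000 nM.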

Compound 3, half-maximal inhibitory concentration: 4400 nM
Estimate against measurement, compound 3: 1.1-fold (0.06 log units) above; measured number inside the range.
By their numbers in this assay, from the lowest: compounds 2, 1 and 3 (each within the scatter of the next).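

In this assay, among these compounds, the exchange of 4-(trifluoromethyl)piperidin-1-yl for 4-methylpiperidin-1-yl gives a 1.3-fold higher number from compound 2 to compound 3 (0.11 log units; within the scatter), the first reading at this position, and it does not separate the two compounds even though the group shrinks from four heavy atoms to one. Among the compounds shown here, until now, the only comparison concerned configuration at a saturated chain carbon, whereas this one shows that, for this pair, the three fluorine atoms on the group three ring bonds from the ring nitrogen can give way to hydrogen atoms without a step beyond the scatter. The compounds shown offer no measured property that would account for this result.

They leave open whether a different group at this ring carbon, such as an amine, a carboxylic acid or a longer chain like n-butyl, would give a step beyond the scatter, since only methyl and trifluoromethyl are compared here. Going by these compounds, it also remains open whether the same exchange reads alike on the other configuration, that of compound 1, and whether any change to the shared core moves the number beyond the scatter.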